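Swapping thiomorpholine for morpholine on a thiosemicarbazone

The source may report more compounds than this note shows. Statements on the series, on what has been measured and on what is new or still open speak of the compounds shown alone.

Measured compounds:
- compound 1 `N/C(=N\NC(=S)N1CCOCC1)c1ccccn1`, 82.8%
- compound 2 `N/C(=N\NC(=S)N1CCCC1)c1ccc(F)cn1`, 81.2%
- compound 3 `N/C(=N\NC(=S)N1CCSCC1)c1ccc(F)cn1`, 81.7%

All three were tested in a functional assay on HeLa cells (Homo sapiens) for cytotoxicity, read by MTT assay, with a stated time of 72 h, tested at 30 uM; on this read-out lower numbers stand for less inhibition of growth and higher numbers for more inhibition of growth at the one concentration tested. Compound 3 stands second of the three numbers: compound 2 sits a step of a number 0.5 percentage points higher from compound 2 to compound 3 (within the scatter) away, while compound 1 differs from compound 3 by an amount that is also within the scatter. In other words, the three measured values cannot be told apart.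

Compound 4 `N/C(=N\NC(=S)N1CCOCC1)c1ccc(F)cn1` has not yet been measured. It arises from compound 3 by the change (morpholin-4-yl in place of thiomorpholin-4-yl on a thiocarbonyl carbon). For the measured compounds named here, the one measured step that bears on this, the exchange of a ring on the thiocarbonyl carbon from compound 2 to compound 3, was a number 0.5 percentage points higher from compound 2 to compound 3 (within the scatter), too small to count. Compound 1, which also carries morpholin-4-yl but lacks the fluorine on the pyridine, gives 82.8%, again within the scatter of compound 3. Going by the values given here, no measured step therefore suggests that this change should move the number beyond the scatter in either direction.

For compound 4 the expected step is a number 0.3 percentage points higher from compound 3 to compound 4 (within the scatter). Compound 4 is estimated at 82%, with a range from 72% to 90%.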

Compound 4, percent growth inhibition at one concentration: 84.5%
Compound 4: middle estimate off by 2.5 percentage points, on the low side; low and high end bracket the measured number.
By their numbers in this assay, from the lowest: compounds 2, 3, 1 and 4 (each within the scatter of the next).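

With the morpholin-4-yl compound added, this assay covers three different rings on the thiocarbonyl carbon over the same core: morpholin-4-yl in place of thiomorpholin-4-yl gives a number 2.8 percentage points higher from compound 3 to compound 4 (within the scatter), and morpholin-4-yl in place of pyrrolidin-1-yl gives a number 3.3 percentage points higher from compound 2 to compound 4 (within the scatter), so neither exchange separates these compounds at this one concentration. For the compounds shown here, the result also gives the first direct comparison of fluoro and hydrogen on an aromatic carbon with the morpholin-4-yl ring held constant, and that change gives a number 1.7 percentage points higher from compound 1 to compound 4 (within the scatter), which likewise cannot be told apart from no change. No measurement is available that would explain why these compounds read so alike.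

As far as these compounds go, it remains open whether a group of a different kind on the thiocarbonyl carbon, such as a piperazine carrying a free amine or an open dimethylamino group, would move the number beyond the scatter. From the compounds shown here alone, it is equally open whether chloro or methoxy in place of fluoro on the aromatic carbon would do so, and whether these four compounds would separate at lower concentrations.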